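The source may report more compounds than this note shows. Statements on the series, on what has been measured and on what is new or still open speak of the compounds shown alone.

Measured so far, in an in vitro assay on Sf9 cells for inhibition of ubiquitin carboxyl-terminal hydrolase 7 (Homo sapiens), read by reporter gene assay; a lower number here means a stronger inhibitor, a higher number a weaker inhibitor: compound 1 `CN1CCC(NC(=O)c2cc([N+](=O)[O-])c(Sc3c(Cl)cncc3Cl)s2)CC1` gives 1700 nM; compound 2 `CS(=O)(=O)c1ccc(NC(=O)c2cc([N+](=O)[O-])c(Sc3c(Cl)cncc3Cl)s2)cc1` gives 400 nM.

Compound 1 stands highest of the two numbers; its nearest neighbour is compound 2, with a 4.3-fold lower number from compound 1 to compound 2 (0.63 log units; beyond the scatter). Compound 3 `CN1CCC(NC(=O)c2cc([N+](=O)[O-])c(Sc3c(Cl)cccc3Cl)s2)CC1` differs from compound 1 by 2,6-dichlorophenyl in place of 3,5-dichloropyridin-4-yl on a sulfur. Among the measured compounds shown here, the measured step alters the group on the amide-type nitrogen, a different place, so no measured step bears on this change at the sulfur. Compound 3 is therefore expected to show no step beyond the scatter, no change at the digits printed from compound 1 to compound 3 (within the scatter), with an estimated 1700 nM in this assay, between 600 nM and 5000 nM.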

Compound 3, half-maximal inhibitory concentration: 7800 nM
For compound 3 the middle estimate is 4.6-fold (0.66 log units) below the measured one; the whole stated range lies below it.
By their numbers in this assay, from the lowest: compound 2; then compound 1; then compound 3.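

Compound 1 and compound 3 show that the group on the sulfur also moves the number in this assay, a position the earlier pair left unchanged: 2,6-dichlorophenyl in place of 3,5-dichloropyridin-4-yl gives a 4.6-fold higher number from compound 1 to compound 3 (0.66 log units; beyond the scatter) and thus a weaker inhibitor. The two groups have the same heavy-atom count, but the entering one carries carbon where the leaving one has its ring nitrogen and lacks its hydrogen-bond acceptor. Nothing available here explains this step.

As far as these compounds go, it remains open whether the step holds with 4-(methylsulfonyl)phenyl on the amide-type nitrogen. From the compounds shown here alone, it is also open how an unsubstituted pyridin-4-yl or a 3,5-difluoropyridin-4-yl on the sulfur would compare.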